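A few compounds are considered here, and "the series" means these few. Any claim that something is new, unique, unknown or untested is made for them only; others in the source may bear on it.

Measured so far in a functional assay on CCRF-CEM cells (Homo sapiens) for antiproliferative activity, with a stated time of 72 h; a lower number here means a stronger inhibitor, a higher number a weaker inhibitor:

- compound 1, `OC[C@H]1O[C@@H](n2cnc3c(NCc4cccc(Br)c4)ncnc32)[C@H](O)[C@@H]1O`: compound 1 gives 5000 nM.
- compound 2, `Cc1ccc(CNc2ncnc3c2ncn3[C@@H]2O[C@H](CO)[C@@H](O)[C@H]2O)cc1`: compound 2 gives only a limit, > 166000 nM.

Compound 2 stands at the weak end of the two values shown; its result is a limit of this assay and not a number, as noted in the limit of > 166000 nM in this assay, at which 1 of the 2 values shown sits. Among the measured compounds shown here, the only step measured is an at least 33-fold higher number from compound 1 to compound 2 (1.52 log units; beyond the scatter), which shows that replacing a halogenated phenyl with a methylated one on the saturated chain carbon bound to the ring nitrogen costs a large amount of potency.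

Compound 3, `OC[C@H]1O[C@@H](n2cnc3c(NCc4ccc(F)cc4F)ncnc32)[C@H](O)[C@@H]1O`, has not been measured. It differs from compound 2 as follows: 2,4-difluorophenyl in place of 4-methylphenyl on a saturated chain carbon bound to a nitrogen on an aromatic ring. This change goes back toward a halogenated phenyl, so the step from compound 1 to compound 2 bears on it in reverse, though the halogen and its placement differ. A gain in this assay is therefore expected, though not necessarily back to the level of compound 1. Compound 3 is estimated at 20000 nM, range 3000 nM to 166000 nM, which means an expected step of an at least 8.3-fold lower number from compound 2 to compound 3 (0.91 log units; beyond the scatter).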

Compound 3, half-maximal inhibitory concentration: 7100 nM
Compound 3: middle estimate off by 2.8-fold (0.45 log units), on the high side; the measured number falls inside the stated range.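

In this assay, setting 2,4-difluorophenyl in place of 4-methylphenyl on a saturated chain carbon bound to a nitrogen on an aromatic ring gives an at least 23-fold lower number from compound 2 to compound 3 (1.36 log units; beyond the scatter), so the steep loss belongs to 4-methylphenyl and does not follow from every departure from 3-bromophenyl at this place. The two halogenated groups differ in halogen and in substitution pattern, yet the comparison reads a 1.4-fold higher number from compound 1 to compound 3 (0.15 log units; within the scatter), so among these three compounds only compound 2 falls away, and this place accepts either halogenated phenyl with no difference that can be read in this assay. On these data alone, the result for compound 2 is a limit of the assay and not a number, so the true size of both steps that touch it stays unknown: the limit of > 166000 nM in this assay, at which 1 of the 3 values shown sits.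

As far as these compounds go, whether the loss follows the methyl group itself or its placement stays open, and 3-methylphenyl, 4-bromophenyl or unsubstituted phenyl at this place would separate the two. Also open, from the compounds shown here alone, is how this place responds to a 2-phenylethyl group in place of the benzyl group, or to an amine or a carboxylic acid on the phenyl ring.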